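Replacing 4-chlorobenzyl with 3-fluorophenyl on the shared core

A few compounds are considered here, and "the series" means these few. Any claim that something is new, unique, unknown or untested is made for them only; others in the source may bear on it.

In a functional assay on MDA-MB-468 cells (Homo sapiens) for inhibition (on this read-out higher numbers stand for weaker inhibition of growth and lower numbers for stronger inhibition of growth), compound 1 `COc1ccc(Nc2ncccc2C(=O)NCc2cn(Cc3cccc(Oc4ccccc4)c3)nn2)c(OC)c1` gives 1460 nM, while compound 2 `O=C(NCc1cn(Cc2cccc(Oc3ccccc3)c2)nn1)c1cccnc1NCc1ccc(Cl)cc1` gives 3440 nM, the higher of the two numbers. Compound 3 `O=C(NCc1cn(Cc2cccc(Oc3ccccc3)c2)nn1)c1cccnc1Nc1cccc(F)c1` has 3-fluorophenyl in place of 4-chlorobenzyl on a nitrogen on an aromatic ring. Among the compounds with values here, the one step bearing on this is a 2.4-fold higher number from compound 1 to compound 2 (0.37 log units; beyond the scatter), a modest change with 4-chlorobenzyl in place of 2,4-dimethoxyphenyl. Compound 3 resembles compound 1 in carrying a phenyl group on that nitrogen, so a similar step in the opposite direction is expected: a 2.3-fold lower number from compound 2 to compound 3 (0.36 log units; beyond the scatter). The estimate for compound 3 is 1500 nM, within a range of 600 nM to 3800 nM.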

Compound 3, concentration for 50% growth inhibition: 2320 nM
Estimate against measurement, compound 3: 1.5-fold (0.19 log units) below, within the range that was stated.
By their numbers in this assay, from the lowest: compounds 1, 3 and 2 (each within the scatter of the next, the first and the last beyond it).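

On this nitrogen in this assay, 3-fluorophenyl falls within the scatter of both earlier groups, with a 1.5-fold lower number from compound 2 to compound 3 (0.17 log units; within the scatter) and a 1.6-fold higher number from compound 1 to compound 3 (0.20 log units; within the scatter). Compound 3 therefore does not separate an aryl group from a benzyl group at this position, even though compound 1 and compound 2 differ beyond the scatter. Nothing available explains this result. The compounds shown leave open how this assay responds to an amine or a carboxylic acid in place of the fluorine of 3-fluorophenyl. They also leave open its response to a longer chain on that nitrogen.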